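Removing the bromoethenyl carbonyl group from compound 2

The source may report more compounds than this note shows. Statements on the series, on what has been measured and on what is new or still open speak of the compounds shown alone.

In a functional assay on HeLa cells (Homo sapiens) for antiproliferative activity, with a stated time of 48 h (on this read-out lower numbers stand for stronger inhibition and higher numbers for weaker inhibition), compound 2 (`C=C(Br)C(=O)Nc1ccc(C(=O)/C=C/c2cc(OC)cc(OC)c2)cc1`) gives 1700 nM and compound 1 (`C=C(Br)C(=O)Nc1ccc(C(=O)/C=C/c2ccc(OC)cc2OC)cc1`) gives 1100 nM, two values within the scatter of each other. Compound 3 (`C=C(Br)C(=O)Nc1ccc(C(=O)/C=C/c2cc(OC)c(OC)c(OC)c2)cc1`) gives 420 nM, clearly apart from both.

Compound 4 (`COc1cc(/C=C/C(=O)c2ccc(N)cc2)cc(OC)c1`) has hydrogen in place of (1-bromoethenyl)carbonyl on a nitrogen on an aromatic ring. Within the data shown here, every measured compound carries that group, so no measured step covers this change. Among the measured compounds shown here, the only step available, a 4.0-fold lower number from compound 2 to compound 3 (0.61 log units; beyond the scatter), is a different change, methoxy in place of hydrogen on an aromatic carbon, and offers only a rough yardstick. A larger step towards a higher number is expected in this assay, namely a 7.1-fold higher number from compound 2 to compound 4 (0.85 log units; beyond the scatter). The estimate for compound 4 is 12000 nM, with a range of 3000 nM to 50000 nM.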

Compound 4, half-maximal inhibitory concentration: 7900 nM
Estimate against measurement, compound 4: 1.5-fold (0.18 log units) above; the range from low to high includes it.
By their numbers in this assay, from the lowest: compound 3; then compounds 1 and 2 (each within the scatter of the next); then compound 4.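

Replacing (1-bromoethenyl)carbonyl with hydrogen on the nitrogen on the aromatic ring gives a 4.6-fold higher number from compound 2 to compound 4 (0.67 log units; beyond the scatter) in this assay. Among these compounds, this is the first read on this position: the value of compound 2 depends in part on that group, yet the amino compound, compound 4, retains a measurable value. No available data explain the step.

Open, as far as these compounds go, is which part of the group matters, the bromine, the double bond or the carbonyl; an acetyl or a propenoyl group on that nitrogen would separate them. Also open, from the compounds shown here alone, is whether the step carries over to the cores of compound 1 and compound 3 .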